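Lengthening the Side Chain of Compound 1

This account rests on a few compounds, and the source may have more. Where it says the series, first, only, none or still open, it means among the compounds named here.

Measured compounds:
compound 1, `C[C@H](NC(=O)CN(c1nc(Cl)nc2[nH]cnc12)C1CC1)C(=O)OCc1ccccc1`, 41.2%
compound 2, `CC[C@H](C)[C@H](NC(=O)CN(c1ncnc2c1ncn2C1CCCCO1)C1CC1)C(=O)OCc1ccccc1`, 25.6%
compound 3, `O=C(CN(c1ncnc2c1ncn2C1CCCCO1)C1CC1)N[C@@H](CO)C(=O)OCc1ccccc1`, 27.8%

In a functional assay on the whole organism (Tail, strain ICR) with Mus musculus as the target, in the tail flick test, with a stated time of 30 min, at a dose of 25 umol/kg by the oral route (a higher number here means a stronger effect of the compound at the dose given, a lower number a weaker effect), compound 1 gives 41.2%, the highest of the three numbers. Compound 3 gives 27.8%, a gap beyond the scatter, and compound 2 gives 25.6%, the furthest below, also beyond the scatter. Compound 4, `CC[C@H](C)[C@H](NC(=O)CN(c1nc(Cl)nc2[nH]cnc12)C1CC1)C(=O)OCc1ccccc1`, has not yet been measured. It differs from compound 1 in one place: sec-butyl in place of methyl on a saturated chain carbon bound to an amide-type nitrogen and a carbonyl carbon. Within the data shown here, only one measured step concerns the same place: a number 2.2 percentage points higher from compound 2 to compound 3 (within the scatter), which stayed within the scatter. That step runs between two compounds sharing the core of compound 2, not the core of compound 1, and it exchanges sec-butyl for hydroxymethyl rather than for methyl, so it is thin evidence; still, it hints that the group on this saturated chain carbon moves the read-out little. The expected outcome is therefore a step of a number 3.2 percentage points lower from compound 1 to compound 4 (within the scatter) in this assay, none beyond the scatter. Compound 4 is estimated at 38%, within a range of 25% to 51%.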

Compound 4, a percentage reported as activity, at one dose (the size of the read-out at that dose, not a potency): 41.4%
Beside the measured number, compound 4's estimate is 3.4 percentage points below it, and the stated range covers the measured number.
By their numbers in this assay, from the lowest: compounds 2 and 3 (each within the scatter of the next); then compounds 1 and 4 (each within the scatter of the next).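

In this assay, sec-butyl in place of methyl on the saturated chain carbon bound to an amide-type nitrogen and a carbonyl carbon gives a number 0.2 percentage points higher from compound 1 to compound 4 (within the scatter) on the core of compound 1, so the larger group leaves the read-out where it was. Among these compounds, the only earlier step at this place, a number 2.2 percentage points higher from compound 2 to compound 3 (within the scatter) on a different core, exchanged sec-butyl for hydroxymethyl and could say nothing about the core of compound 1; with this new step, a flat result at this place is seen on both cores. Nothing available here accounts for this flat result.

On these data alone, whether a carboxylic acid, an amine or a longer chain on this carbon would also stay within the scatter remains open. So does whether hydroxymethyl would behave on the core of compound 1 as it did on the core of compound 2.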